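A repeated methyl-to-trifluoromethoxy swap predicts compound 4

The source may hold more compounds than are shown below. What is called first, only, known or untested is meant among the compounds shown, and "the series" means these compounds.

Compound 1 `Cc1ccc(S(=O)(=O)N2C(=O)COC23C=CC(=O)C=C3)cc1` anchors this small set. In a functional assay on HeLa cells (Homo sapiens) for inhibition, read by sulforhodamine B assay, with a stated time of 74 h (a higher number here means a weaker inhibitor, a lower number a stronger inhibitor), compound 1 gives 180 nM. Compound 2 `Cc1ccccc1S(=O)(=O)N1C(=O)COC12C=CC(=O)C=C2` holds the same atoms joined differently, the cores differing by 2-methylphenyl in place of 4-methylphenyl on a sulfonyl sulfur, and the rearrangement costs a 21-fold higher number from compound 1 to compound 2 (1.32 log units; beyond the scatter); in this assay compound 2 gives 3720 nM. Compound 3 `O=C1C=CC2(C=C1)OCC(=O)N2S(=O)(=O)c1ccc(OC(F)(F)F)cc1` carries trifluoromethoxy in place of methyl on an aromatic carbon. In this assay compound 3 reaches only a limit, > 10000 nM. The step is thus an at least 55-fold higher number from compound 1 to compound 3 (1.74 log units; beyond the scatter), its floor fixed by the limit of > 10000 nM in this assay, at which 1 of the 3 values shown sits. Compound 4 `O=C1C=CC2(C=C1)OCC(=O)N2S(=O)(=O)c1ccccc1OC(F)(F)F` is unmeasured and differs from compound 2 by trifluoromethoxy in place of methyl on an aromatic carbon; this is the same kind of change as from compound 1 to compound 3, though the place differs, being ortho to a large group rather than para to a large group. Resting on an at least 55-fold higher number from compound 1 to compound 3 (1.74 log units; beyond the scatter), the expectation for compound 4 is an 8.1-fold higher number from compound 2 to compound 4 (0.91 log units; beyond the scatter). Compound 4 is estimated at 30000 nM, between 8000 nM and 120000 nM, and would most likely be reported only as a limit.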

Compound 4, half-maximal inhibitory concentration: 140 nM
The estimate for compound 4 lay 210-fold (2.33 log units) above the measured number; the whole stated range lies above it.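

In this assay, trifluoromethoxy in place of methyl gave a 27-fold lower number from compound 2 to compound 4 (1.42 log units; beyond the scatter), the opposite direction to the earlier step, so the change did not carry from one core to the other: the same change on two cores in this assay, an at least 55-fold higher number (1.74 log units; beyond the scatter) from compound 1 to compound 3 and a 27-fold lower number (1.42 log units; beyond the scatter) from compound 2 to compound 4, at least 1400-fold (3.16 log units) apart, beyond the scatter of two such steps. From the compounds shown here alone, the earlier step ends at a limit for compound 3, so its full size stays open: the limit of > 10000 nM in this assay, at which 1 of the 4 values shown sits. Two pairs establish no rule for the series, and they do not show what lies behind the reversal.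

The compounds shown leave open how a methoxy group or an amine would behave ortho to a large group on the same ring. They also leave open whether a carboxylic acid or a longer chain there would follow compound 2 or compound 4.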